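The compounds below may be only part of what the source reports. "The series", "measured", "known", "first", "only" and "open" are said of these compounds alone.

Among the measured compounds shown here, in an assay on Sf9 cells for inhibition of protein deacetylase HDAC6 (Homo sapiens), read by fluorescence (a lower number here means a stronger inhibitor, a higher number a weaker inhibitor), compound 2 `O=C(NO)c1ccc(Cn2nnc(-c3ccccc3)n2)cc1` gives 3 nM, the lowest of the two numbers measured so far. Its nearest neighbour, compound 1 `O=C(NO)c1ccc(Cn2nnc(-c3ncccn3)n2)cc1`, gives 7 nM in this assay, separated from it by the step of a 2.3-fold lower number from compound 1 to compound 2 (0.37 log units; beyond the scatter). Compound 3 `Nc1ccc(-c2nnn(Cc3ccc(C(=O)NO)cc3)n2)cc1` differs from compound 2 by amino in place of hydrogen on an aromatic carbon. For the measured compounds named here, no measured step concerns an amino group; the only known step, a 2.3-fold lower number from compound 1 to compound 2 (0.37 log units; beyond the scatter), swaps one ring for another, so it offers little guidance here. Compound 3 is therefore expected to change by a 1.3-fold higher number from compound 2 to compound 3 (0.12 log units; within the scatter) in this assay, a step within the scatter. The estimate for compound 3 is 4 nM, ranging from 1.5 nM to 12 nM.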

Compound 3, half-maximal inhibitory concentration: 1 nM
Estimate against measurement, compound 3: 4.0-fold (0.60 log units) above; the measured number lies below the stated range.
By their numbers in this assay, from the lowest: compound 3; then compound 2; then compound 1.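

In this assay the change from phenyl to 4-aminophenyl, with amino para to a large group, is a 3.0-fold lower number from compound 2 to compound 3 (0.48 log units; beyond the scatter) and shows that adding a group at this place can lower the number, which the earlier ring swap could not show. Against the pyrimidin-2-yl compound, the same ring carrying amino gives a 7.0-fold lower number from compound 1 to compound 3 (0.85 log units; beyond the scatter) and so extends the range seen so far. No measurement here explains why amino lowers the number.
As far as these compounds go, whether this belongs to amino itself remains open. A hydroxyl, a methoxy group or a longer amine at the same place could behave alike or differently.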